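Benzylthio-purine nucleosides: varying the benzyl ring substituent

This account rests on a few compounds, and the source may have more. Where it says the series, first, only, none or still open, it means among the compounds named here.

Measured so far:
compound 1 `OC[C@H]1O[C@@H](n2cnc3c(SCc4ccccc4Br)ncnc32)[C@H](O)[C@@H]1O` — 151 nM
compound 2 `OC[C@H]1O[C@@H](n2cnc3c(SCc4cccc(C(F)(F)F)c4)ncnc32)[C@H](O)[C@@H]1O` — 19.1 nM

In an assay on isolated protein for inhibition of Equilibrative nucleoside transporter 1 (Homo sapiens) (on this read-out higher numbers stand for weaker inhibition and lower numbers for stronger inhibition), compound 1 gives 151 nM, the highest of the two numbers; compound 2 gives 19.1 nM. Going by the values given here, the one step in hand, a 7.9-fold lower number from compound 1 to compound 2 (0.90 log units; beyond the scatter), changes the same ring as the step now considered. Compound 3 `OC[C@H]1O[C@@H](n2cnc3c(SCc4ccc(Cl)c(Cl)c4)ncnc32)[C@H](O)[C@@H]1O` differs from compound 1 as follows: 3,4-dichlorophenyl in place of 2-bromophenyl on a saturated chain carbon bound to a sulfur. Both changes move substitution away from the 2-position pattern of compound 1, so a similar drop is expected, though a single comparison is a thin basis; the step is estimated as a 4.3-fold lower number from compound 1 to compound 3 (0.63 log units; beyond the scatter). Compound 3 is expected at 35 nM, within 9 nM to 130 nM.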

Compound 3, inhibition constant: 12.6 nM
For compound 3 the middle estimate is 2.8-fold (0.44 log units) above the measured one, within the range that was stated.
By their numbers in this assay, from the lowest: compounds 3 and 2 (each within the scatter of the next); then compound 1.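

The step to the 3,4-dichlorophenyl group, a 12-fold lower number from compound 1 to compound 3 (1.08 log units; beyond the scatter), shows that a second substitution pattern lacking the 2-bromophenyl arrangement also gives a clearly lower number than compound 1. The 3,4-dichlorophenyl and 3-(trifluoromethyl)phenyl groups cannot be told apart at this position, with a 1.5-fold lower number from compound 2 to compound 3 (0.18 log units; within the scatter). Nothing in hand gives a reason for either step.

Open, as far as these compounds go, is how a benzyl ring carrying an amine or a carboxylic acid would compare with compound 2 and compound 3. Also open, from the compounds shown here alone, is whether a longer chain between the sulfur and the ring keeps these numbers.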